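Dropping the benzyl group: from compound 2 to compound 3

The source may report more compounds than this note shows. Statements on the series, on what has been measured and on what is new or still open speak of the compounds shown alone.

Compound 1 `C[Se]c1nc(N)c2ccccc2n1`: 59000 nM
Compound 2 `CCCCC[Se]c1nc(NCc2ccccc2)c2ccccc2n1`: > 100000 nM

In an ADME assay on 184B5 cells (Homo sapiens) for cytotoxicity, read by MTT assay, with a stated time of 72 h (a higher number here means a weaker inhibitor of growth, a lower number a stronger inhibitor of growth), compound 1 gives 59000 nM. For compound 2 the assay reports only a limit, > 100000 nM, which is the limit of > 100000 nM in this assay, at which 1 of the 2 values shown sits, so compound 2 stands at the edge of what the assay measures. Compound 3 `CCCCC[Se]c1nc(N)c2ccccc2n1` has not been measured; it differs from compound 2 by hydrogen in place of benzyl on a nitrogen on an aromatic ring. Within the data shown here, no measured pair shows this change, so the expected step of an at least 1.2-fold lower number from compound 2 to compound 3 (0.09 log units; that floor lies within the scatter) is small and uncertain in direction. Compound 3 is estimated at 80000 nM, between 40000 nM and 160000 nM.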

Compound 3, concentration for total growth inhibition: 43600 nM
The estimate for compound 3 lay 1.8-fold (0.26 log units) above the measured number, and the stated range covers the measured number.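

In this assay, the amino compound gives the first readable effect at this nitrogen, where benzylamino to amino brings an at least 2.2-fold lower number from compound 2 to compound 3 (0.36 log units; beyond the scatter). Compound 2 remains a limit of the assay, so this step is only a bound: the limit of > 100000 nM in this assay, at which 1 of the 3 values shown sits.

The chain on selenium shows no separable effect, with butyl in place of hydrogen on a saturated chain carbon bound to a selenium atom giving a 1.4-fold lower number from compound 1 to compound 3 (0.13 log units; within the scatter). Going by these compounds, whether methyl on that nitrogen would stand nearer compound 3 or compound 2 stays open. So does the effect of a longer chain or an amine on the chain on selenium.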